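Oral exposure of an indane analogue: an expectation

The source may report more compounds than this note shows. Statements on the series, on what has been measured and on what is new or still open speak of the compounds shown alone.

Measured compounds:
compound 1 `CCC(=O)Nc1cc(Nc2ncc(Br)c(Nc3ccc4cc[nH]c4c3)n2)c(OC)cc1N1CCN(C)CC1`: 445 nM
compound 2 `C=CC(=O)Nc1cc(Nc2ncc(Br)c(Nc3ccc4ccn(C)c4c3)n2)c(OC)cc1N1CCN(C)CC1`: 1080 nM

In an ADME assay on the whole organism (Rattus norvegicus, strain Sprague-Dawley) for pharmacokinetics, read by LC-MS, with a stated time of 24 h, at a dose of 10 mg/kg by the oral route (a lower number here means less compound in the circulation, a higher number more compound in the circulation at the dose given), compound 1 gives 445 nM and compound 2 gives 1080 nM. Compound 2 therefore stands highest of the two numbers, and its gap to compound 1 lies beyond the scatter. Compound 3 `C=CC(=O)Nc1cc(Nc2ncc(Br)c(Nc3ccc4c(c3)CCC4)n2)c(OC)cc1N1CCN(C)CC1` differs from compound 2 by 2,3-dihydro-1H-inden-5-yl in place of 1-methyl-1H-indol-6-yl on a nitrogen on an aromatic ring. Among the compounds with values here, no measured pair shows this change, so the step of a 1.1-fold lower number from compound 2 to compound 3 (0.03 log units; within the scatter) is expected to be none beyond the scatter. Compound 3 is thus estimated at 1000 nM, with a range from 350 nM to 3000 nM.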

Compound 3, maximal plasma concentration: 781 nM
Compound 3: middle estimate off by 1.3-fold (0.11 log units), on the high side; the measured number falls inside the stated range.
By their numbers in this assay, from the lowest: compounds 1, 3 and 2 (each within the scatter of the next, the first and the last beyond it).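

In this assay there is a 1.4-fold lower number from compound 2 to compound 3 (0.14 log units; within the scatter) when 2,3-dihydro-1H-inden-5-yl replaces 1-methyl-1H-indol-6-yl on a nitrogen on an aromatic ring, the first single-place step shown at this position. A five-membered non-aromatic ring of carbon only thus stands in for a five-membered aromatic ring with one hetero atom without a change beyond the scatter. Nothing measured here accounts for this result.

Still open, on these data alone, is whether the number would hold with a group of another kind at this position, such as a phenyl ring carrying a carboxylic acid or a dimethylamino group.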